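Adding a Methyl to the Amine of Compound 3

A few compounds are considered here, and "the series" means these few. Any claim that something is new, unique, unknown or untested is made for them only; others in the source may bear on it.

Compound 1 `CCN(C)CCCOc1ccc2cc(NC(=O)c3ccc(O)c(CC=C(C)C)c3)c(=O)oc2c1C`: 2190 nM
Compound 2 `CC(C)=CCc1cc(C(=O)Nc2cc3ccc(OCCCNCC(=O)O)c(C)c3oc2=O)ccc1O`: 18100 nM
Compound 3 `CC(C)=CCc1cc(C(=O)Nc2cc3ccc(OCCCNC4CCCCC4)c(C)c3oc2=O)ccc1O`: 1070 nM

These values come from a functional assay on MCF7 cells (Homo sapiens) for antiproliferative activity; a higher number here means a weaker inhibitor, a lower number a stronger inhibitor. Compound 3 gives the lowest number of the three, 1070 nM. The measurements show a 2.0-fold lower number from compound 1 to compound 3 (0.31 log units; beyond the scatter), a modest step, and a 17-fold lower number from compound 2 to compound 3 (1.23 log units; beyond the scatter), a large one. Compound 4 `CC(C)=CCc1cc(C(=O)Nc2cc3ccc(OCCCN(C)C4CCCCC4)c(C)c3oc2=O)ccc1O` carries methyl in place of hydrogen on an amine nitrogen, methyl in place of hydrogen on an amine nitrogen. Among the compounds with values here, no measured step makes this exact change. The modest 2.0-fold lower number from compound 1 to compound 3 (0.31 log units; beyond the scatter) is the closest guide, though it exchanges ethyl(methyl)amino for cyclohexylamino. The large 17-fold lower number from compound 2 to compound 3 (1.23 log units; beyond the scatter) concerns carboxymethyl and bears less directly. A small rise is therefore expected, amounting to an estimated 1.2-fold higher number from compound 3 to compound 4 (0.08 log units; within the scatter). Compound 4 is expected at 1300 nM, with an estimated range of 600 nM to 2800 nM.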

Compound 4, half-maximal inhibitory concentration: 1080 nM
For compound 4 the middle estimate is 1.2-fold (0.08 log units) above the measured one; the range from low to high includes it.
By their numbers in this assay, from the lowest: compounds 3 and 4 (each within the scatter of the next); then compound 1; then compound 2.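

In this assay, methyl in place of hydrogen on the amine nitrogen leaves the result within the scatter, with a 1.0-fold higher number from compound 3 to compound 4 (0.00 log units; within the scatter), so this nitrogen carries either substituent without a readable difference. With that methyl in place, cyclohexyl in place of ethyl gives a 2.0-fold lower number from compound 1 to compound 4 (0.31 log units; beyond the scatter), and cyclohexyl(methyl)amino in place of (carboxymethyl)amino gives a 17-fold lower number from compound 2 to compound 4 (1.22 log units; beyond the scatter), matching the steps seen with compound 3. No measurement shown here explains these results. The compounds shown leave open how a benzyl group on this nitrogen, or a morpholine ring in place of the cyclohexyl(methyl)amino group, would read in this assay.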